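Chromene series: an aryl ketone bearing a free hydroxyl

The compounds below may be only part of what the source reports. "The series", "measured", "known", "first", "only" and "open" are said of these compounds alone.

Measured so far in a functional assay (aorta) with Rattus norvegicus as the target; on this read-out higher numbers stand for higher potency (the scale is a negative logarithm) and lower numbers for lower potency:
- compound 1, `COc1ccc2c(c1)C(n1ccccc1=O)=CC(C)(C)O2`, 6.55
- compound 2, `CCC(=O)c1ccc2c(c1)C(n1ccccc1=O)=CC(C)(C)O2`, 6.63
- compound 3, `COc1ccc(C(=O)c2ccc3c(c2)C(n2ccccc2=O)=CC(C)(C)O3)cc1`, 6.15

Compound 1 stands second highest of the three. Its nearest neighbour is compound 2, with a number 0.08 log units higher from compound 1 to compound 2 (within the scatter). The furthest is compound 3; the values of compound 1 and compound 3 differ by a margin that is beyond the scatter, compound 3 giving the lower number.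

The next compound, compound 4, `CC1(C)C=C(n2ccccc2=O)c2cc(C(=O)c3ccc(O)cc3)ccc2O1`, is reached from compound 1 by one change: (4-hydroxyphenyl)carbonyl in place of methoxy on an aromatic carbon. Going by the values given here, two measured steps bear on it. Replacing methoxy with a ketone gave a number 0.08 log units higher from compound 1 to compound 2 (within the scatter), while replacing ethyl with an aryl group on the carbonyl gave a number 0.48 log units lower from compound 2 to compound 3 (beyond the scatter). Compound 4 carries an aryl ketone like compound 3, so a modest drop from compound 1 is expected, near that seen from compound 2 to compound 3. Compound 4 is therefore estimated at 6.2 in this assay, within 5.7 to 6.7, meaning an expected step of a number 0.35 log units lower from compound 1 to compound 4 (beyond the scatter).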

Compound 4, logarithm of the reciprocal of the active concentration, log(1/C): 6.65
Compound 4: the middle estimate sits 0.45 log units below what was measured; low and high end bracket the measured number.
By their numbers in this assay, from the lowest: compound 3; then compounds 1, 2 and 4 (each within the scatter of the next).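

Notes on the aryl ketone: in this assay, hydrogen in place of methyl on an oxygen on an aromatic ring accounts for the whole of the one change separating the two aryl ketones (a number 0.50 log units higher from compound 3 to compound 4 (beyond the scatter)). An aryl ketone at this position therefore does not by itself go with a lower number, and of the three aryl or alkyl ketones and ethers here only compound 3 stands apart. (4-Hydroxyphenyl)carbonyl can replace methoxy on this aromatic carbon (a number 0.10 log units higher from compound 1 to compound 4 (within the scatter)), and 4-hydroxyphenyl can replace ethyl on the carbonyl carbon (a number 0.02 log units higher from compound 2 to compound 4 (within the scatter)), with no step beyond the scatter.

Nothing in the data gives a measured reason for the gap between the free hydroxyl and the methylated oxygen.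

From the compounds shown here alone, whether an amine or a carboxylic acid in place of that hydroxyl keeps the number remains open, as does the effect of a longer chain than methyl on that oxygen.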